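Removing the fluoro from compound 1

A few compounds are considered here, and "the series" means these few. Any claim that something is new, unique, unknown or untested is made for them only; others in the source may bear on it.

Going by the values given here, compound 1 `CN1CCC(c2ccc3c(c2)oc(=O)n3C(=O)NCCCCc2ccc(F)cc2)CC1` is one of three compounds measured in an assay on HEK293 cells for inhibition of acid ceramidase (Homo sapiens), read by fluorescence, with stated times of 10 min and 3 h (a lower number here means a stronger inhibitor, a higher number a weaker inhibitor), where compound 1 gives 94 nM. Compound 3 `CCCCCNC(=O)n1c(=O)oc2cc(-c3ccc(F)cc3)ccc21` gives 60 nM in this assay, a number within the scatter of that for compound 1, so these two cannot be placed in order on the present data. Compound 2 `CC(C)CNC(=O)n1c(=O)oc2c(C3CCN(C)CC3)cccc21` gives 535 nM in this assay, a higher number than compound 1 by a margin beyond the scatter. Compound 1 thus stands together with compound 3 on the lower side of this small set, with compound 2 set apart.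

The next compound, compound 4 `CN1CCC(c2ccc3c(c2)oc(=O)n3C(=O)NCCCCc2ccccc2)CC1`, differs from compound 1 in one place: hydrogen in place of fluoro on an aromatic carbon. Put another way, the 4-fluorophenyl at the end of the chain in compound 1 becomes a phenyl in compound 4. Among the compounds with values here, no pair of measured compounds shows this change on its own, so its size cannot be read from the numbers at hand.

The step is expected to be small, a 1.4-fold higher number from compound 1 to compound 4 (0.14 log units; within the scatter), leaning toward a higher number but not beyond the scatter. Compound 4 is therefore estimated to give 130 nM in this assay, with a likely range from 60 nM to 280 nM.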

Compound 4, half-maximal inhibitory concentration: 129 nM
Beside the measured number, compound 4's estimate is 1.0-fold (0.00 log units) above it, within the range that was stated.
By their numbers in this assay, from the lowest: compounds 3, 1 and 4 (each within the scatter of the next, the first and the last beyond it); then compound 2.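

In this assay, going by these compounds alone, the change from 4-fluorophenyl to phenyl at the end of the chain gives a 1.4-fold higher number from compound 1 to compound 4 (0.14 log units; within the scatter), and this is the first step that isolates a single place. On these numbers, fluoro and hydrogen at this aromatic carbon cannot be told apart, so within this pair the fluoro is not needed to keep compound 4 in the same range as compound 1, and the step says nothing about groups other than these two. No supporting data bear on this result, so it stands as an observation on one pair of compounds.

Still open, going by these compounds, is how much this place tolerates when the group is larger or differs in kind, such as chloro, methoxy, trifluoromethyl, an amine or a carboxylic acid on the same aromatic carbon. Also open, on these data alone, are whether a shorter or longer chain to the phenyl changes the picture, and whether hydrogen and fluoro remain indistinguishable on a phenyl ring attached elsewhere on the shared core.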